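This account rests on a few compounds, and the source may have more. Where it says the series, first, only, none or still open, it means among the compounds named here.

Measured compounds:
Compound 1 `Cc1ccc(Nc2nc(-c3ccccc3)c(C#N)c(N3CCCCC3)n2)cc1` — 10%
Compound 2 `N#Cc1c(NC2CCCCC2)nc(SCc2ccccc2)nc1-c1ccc(Cl)cc1` — 0%

Of the compounds shown here, two have been measured in an ADME assay on Jurkat cells (Homo sapiens) for inhibition, read by WST assay, with a stated time of 48 h, tested at 10 uM; on this read-out higher numbers stand for more inhibition at the one concentration tested (going by the name of the read-out) and lower numbers for less inhibition. Compound 1 `Cc1ccc(Nc2nc(-c3ccccc3)c(C#N)c(N3CCCCC3)n2)cc1` gives 10% in this assay. Compound 2 `N#Cc1c(NC2CCCCC2)nc(SCc2ccccc2)nc1-c1ccc(Cl)cc1` gives 0% in this assay. These two numbers lie within the usual scatter of each other, so the data show no real difference between compound 1 and compound 2; both sit at the low end of what this read-out can report, and neither shows inhibition of note at the one concentration tested.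

Compound 3 `N#Cc1c(-c2ccc(Cl)cc2)nc(SCc2ccccc2)nc1N1CCC(C(N)=O)CC1` has not yet been measured in this assay. It differs from compound 2 in one place: 4-carbamoylpiperidin-1-yl in place of cyclohexylamino on an aromatic carbon. For the measured compounds named here, no pair of measured compounds separates this change, so no step of known size can be drawn on. With the two measured values both close to zero and within the scatter of each other, the expected step of a number 5 percentage points higher from compound 2 to compound 3 (within the scatter) is none beyond the scatter, in no particular direction. Compound 3 is therefore estimated to give 5%, in the range 0% to 20%, in this assay.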

Compound 3, a percentage reported as inhibition, at one concentration (the size of the read-out at that concentration, not a potency): 19%
For compound 3 the middle estimate is 14 percentage points below the measured one; low and high end bracket the measured number.
By their numbers in this assay, from the lowest: compounds 2, 1 and 3 (each within the scatter of the next, the first and the last beyond it).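

In this assay, for the compounds shown here, the exchange of cyclohexylamino for 4-carbamoylpiperidin-1-yl, on the aromatic carbon ortho to a cyano group, gives a number 19 percentage points higher from compound 2 to compound 3 (beyond the scatter) and is the first single change in this set with a readable size. It shows that this position is not silent: with the 4-chlorophenyl and benzylsulfanyl groups held constant, the group placed here alone moves the read-out, although compound 3 reaches only 19% at the one concentration tested. Nothing available accounts for this step, so the reason for it remains unknown.

The compounds shown leave open whether the step belongs to the six-membered ring attached through its nitrogen or to the carbamoyl group it carries, a question that piperidin-1-yl itself, or a carboxylic acid in place of the carbamoyl group on the same ring, would help to settle at this position. As far as these compounds go, it also remains open whether the same exchange would give a step of similar size with other groups in place of the 4-chlorophenyl or benzylsulfanyl groups on the shared core.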